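A few compounds are considered here, and "the series" means these few. Any claim that something is new, unique, unknown or untested is made for them only; others in the source may bear on it.

Measured in a functional assay on MDA-MB-231 cells (Homo sapiens) for antiproliferative activity, read by MTT assay, with a stated time of 24 h; on this read-out higher numbers stand for weaker inhibition and lower numbers for stronger inhibition:
- Compound 1 `CCCCc1oc2ccccc2c1C(=O)c1ccc(OCC(=O)NC(C)C)cc1`: > 50000 nM (a limit)
- Compound 2 `CCCCc1oc2ccccc2c1C(=O)c1ccc(OCC(=O)N2CCCCC2)cc1`: > 50000 nM (a limit)
- Compound 3 `CCCCc1oc2ccccc2c1C(=O)c1ccc(OCCCC(=O)N2CCOCC2)cc1`: 31600 nM

Among the measured compounds shown here, compound 3, at 31600 nM, holds the only actual number in this small set. The other two results give no number: they stand at the limit of > 50000 nM in this assay, at which 2 of the 3 values shown sit.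

Compound 4 `CCCCc1oc2ccccc2c1C(=O)c1ccc(OCCCC(=O)N[C@H](C)c2ccccc2)cc1` keeps the chain of compound 3 and changes its amide: (1-phenylethyl)amino in place of morpholin-4-yl on a carbonyl carbon. Two measured steps end at compound 3, and each replaces the whole side group: an at least 1.5-fold lower number from compound 1 to compound 3 (0.19 log units; that floor lies within the scatter), and an at least 1.5-fold lower number from compound 2 to compound 3 (0.19 log units; that floor lies within the scatter). Neither isolates the change at the carbonyl carbon. For the measured compounds named here, the one step confined to that place is a step that the two limits leave unreadable from compound 1 to compound 2, so it gives no size to carry over.

With no readable step beyond the scatter to draw on, no clear shift is expected in this assay, and a result reported only as a limit remains possible. The expected change is a 1.1-fold lower number from compound 3 to compound 4 (0.05 log units; within the scatter). For compound 4 the estimated value is 28000 nM, with an expected range of 9000 nM to 50000 nM.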

Compound 4, half-maximal inhibitory concentration: > 50000 nM
Compound 4 ended at the assay's limit (the forecaster's own chance of this, stated with the estimate: 35%); middle value at least 1.7-fold (0.25 log units) from the limit.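

In this assay, among the compounds shown here, (1-phenylethyl)amino in place of morpholin-4-yl on a carbonyl carbon gives the first step confined to that place that can be read at all, while the earlier step at this carbon cannot be read: an at least 1.5-fold higher number from compound 3 to compound 4 (0.19 log units; that floor lies within the scatter). For the compounds shown here, this step keeps the chain of compound 3, so it separates the amide from the chain, which the earlier steps to compound 3 did not do. Compound 4 carries that same chain and still gives only a limit, so the chain alone does not yield a number in this assay: the limit of > 50000 nM in this assay, at which 3 of the 4 values shown sit.

Going by these compounds, how far compound 4 lies past its limit stays unknown, and so does the true size of the step. Also open, on these data alone, is how a piperazin-1-yl group, a benzylamino group or the other stereoisomer of the (1-phenylethyl)amino group would read on this carbonyl carbon.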